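The source may hold more compounds than are shown below. What is called first, only, known or untested is meant among the compounds shown, and "the series" means these compounds.

Measured so far:
- compound 1 `CC(C)(C)OC(=O)N1CCC(O[C@H]2CC[C@H](Oc3ccc(S(C)(=O)=O)cc3)CC2)CC1`: 120%
- compound 2 `CC(C)(C)OC(=O)N1CCC(O[C@H]2CC[C@H](Oc3ccc(S(C)(=O)=O)cc3F)CC2)CC1`: 119%

In a functional assay on isolated protein for agonist activity at Glucose-dependent insulinotropic receptor (Rattus norvegicus), read by HTRF and cAMP accumulation (a higher number here means a larger maximal response, a lower number a smaller maximal response), compound 1 stands with the highest of the two numbers, and compound 2 is nearest with a number 1 percentage points lower from compound 1 to compound 2 (within the scatter), so the two sit within the scatter of each other and no order can be read from them.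

Compound 3 `CC(C)(C)OC(=O)N1CCC(O[C@H]2CC[C@H](Oc3ccc(S(C)(=O)=O)c(F)c3)CC2)CC1` is the next member. Compared with compound 1 the change is fluoro in place of hydrogen on an aromatic carbon. For the measured compounds named here, the one measured step that bears on it is the exchange of fluoro for hydrogen on an aromatic carbon of the same ring, a number 1 percentage points lower from compound 1 to compound 2 (within the scatter), which produced no movement beyond the scatter. On that basis the same kind of exchange in compound 3 is expected to give a step of about a number 2 percentage points lower from compound 1 to compound 3 (within the scatter), that is, none beyond the scatter. The maximal response of compound 3 is therefore estimated at 118%, with a range of 105% to 130%.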

Compound 3, largest response reached (Emax), in percent of the reference or control that the assay uses: 109%
The estimate for compound 3 lay 9 percentage points above the measured number, and the stated range covers the measured number.
By their numbers in this assay, from the lowest: compounds 3, 2 and 1 (each within the scatter of the next, the first and the last beyond it).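

At this carbon, ortho to a methylsulfonyl group and meta to a large group, the exchange is not neutral: in this assay it gives a number 11 percentage points lower from compound 1 to compound 3 (beyond the scatter), the only step shown that lies beyond the scatter, whereas the same exchange elsewhere on this ring gave a number 1 percentage points lower from compound 1 to compound 2 (within the scatter). Sensitivity to fluoro therefore depends on the carbon that carries it, although compounds 2 and 3 remain within the scatter of each other and cannot be ordered. Nothing available gives a reason for this step.

The compounds shown leave open whether the step is specific to fluoro or would also appear with chloro, methoxy or a nitrile at this carbon. They also leave open whether the carbon stays sensitive when an amine or a carboxylic acid replaces the methylsulfonyl group.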